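A few compounds are considered here, and "the series" means these few. Any claim that something is new, unique, unknown or untested is made for them only; others in the source may bear on it.

Measured so far in a physicochemical assay for lipophilicity, using the shake flask method; a lower number here means a more polar compound, a higher number a more lipophilic compound:
compound 1 `Cc1c(/C=C/C(=O)O)cnc2ccc(O[C@@H](C)c3c(Cl)ccc(F)c3Cl)cc12` gives 3
compound 2 `C[C@H](Oc1ccc2ncc(/C=C/c3nn[nH]n3)c(C3CC3)c2c1)c1c(Cl)ccc(F)c1Cl` gives 3.7
compound 3 `CC(Oc1ccc2ncc(/C=C/C(=O)O)cc2c1)C1CCCCC1` gives 3

Compound 1 stands level with compound 3 within the scatter, the two together at the low end of these three numbers, while compound 2 lies higher, beyond the scatter. The unmeasured compound 4 `C[C@H](Oc1ccc2ncc(/C=C/C(=O)O)c(O)c2c1)c1c(Cl)ccc(F)c1Cl` carries hydroxy in place of methyl on an aromatic carbon, ortho to a 2-carboxyethenyl group and opposite the ring nitrogen (hydroxy in place of methyl on an aromatic carbon). Among the measured compounds shown here, no two measured compounds differ in one place only, so the expectation rests on this structural change alone: a moderate fall in this assay rather than a rise. The expected change is a number 0.70 log units lower from compound 1 to compound 4 (beyond the scatter) on this estimate. For compound 4 the estimated value is 2.3 with an expected range from 1.7 to 2.9 in this measurement.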

Compound 4, distribution coefficient: 1.9
Compound 4: middle estimate off by 0.40 log units, on the high side; measured number inside the range.
By their numbers in this assay, from the lowest: compound 4; then compounds 1 and 3 (each within the scatter of the next); then compound 2.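

In this assay, among the compounds shown here, the change of methyl to hydroxy on this aromatic carbon, ortho to a 2-carboxyethenyl group and opposite the ring nitrogen, gives a number 1.10 log units lower from compound 1 to compound 4 (beyond the scatter) and is the only single-place step read so far. This position is therefore not silent in this measurement: exchanging one heavy atom here moves the number beyond the scatter. No measured evidence on hand accounts for the size of the step. Going by these compounds, whether methoxy or an amine on this carbon would move the number as far remains open, as does whether the step carries over to other compounds.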